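From compound 2 to compound 3: a ring swap

This account rests on a few compounds, and the source may have more. Where it says the series, first, only, none or still open, it means among the compounds named here.

Measured in an ADME assay on ECV-304 cells (Homo sapiens) for cytotoxicity, read by MTT assay, with a stated time of 72 h (on this read-out higher numbers stand for weaker inhibition and lower numbers for stronger inhibition), are these compounds:
Compound 1 `COc1ccc(C2=C(c3cc(OC)c(OC)c(OC)c3)C(=O)C(O[SiH2]C(C)(C)C)C2)cc1` gives 16 ug/mL
Compound 2 `COc1ccc(C2=C(c3cc(OC)c(OC)c(OC)c3)C(=O)C(O[SiH2]C(C)(C)C)C2)cc1OC(C)C` gives > 100 ug/mL as a limit and not a number

Compound 2 thus stands at a limit, with no exact value. Compound 3 `COc1cc(C2=C(c3ccc(SC)cc3)CC(O[SiH2]C(C)(C)C)C2=O)cc(OC)c1OC` differs from it in one place 4-(methylsulfanyl)phenyl in place of 3-isopropoxy-4-methoxyphenyl on a double-bonded ring carbon with 4-(methylsulfanyl)phenyl in place of 3-isopropoxy-4-methoxyphenyl on a double-bonded ring carbon. For the measured compounds named here, the one measured step that bears on this is an at least 6.2-fold higher number from compound 1 to compound 2 (0.79 log units; beyond the scatter) where isopropoxy replaced hydrogen on an aromatic carbon. Compound 3 carries no isopropoxy, like compound 1 at 16 ug/mL so a return towards that level is expected. Going by the values given here, no measured step covers the 4-(methylsulfanyl)phenyl group. The expected change is an at least 5.0-fold lower number from compound 2 to compound 3 (0.69 log units; beyond the scatter) in this assay towards stronger inhibition. The estimate for compound 3 is 20 ug/mL with 6 ug/mL to 70 ug/mL as its expected range.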

Compound 3, half-maximal inhibitory concentration: > 100 ug/mL
Compound 3: only a limit was reported; the forecaster's own chance of this, stated with the estimate: 15%; middle value at least 5.0-fold (0.69 log units) away from the limit.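

Even without an isopropoxy group, the number does not return to the level of compound 1: methylsulfanyl in place of methoxy on an aromatic carbon gives an at least 6.2-fold higher number from compound 1 to compound 3 (0.79 log units; beyond the scatter). Among these three compounds, then, the isopropoxy group is not the only change on this ring that moves the number upward. The step from compound 2 to compound 3 cannot be read, because both compounds sit at the same limit: the limit of > 100 ug/mL in this assay, at which 2 of the 3 values shown sit.

From the compounds shown here alone, how far compound 2 and compound 3 lie past that limit stays open. So does whether a smaller group in place of methylsulfanyl, such as a hydroxy group or an amine, would bring the number back towards that of compound 1.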